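Removing the Thiazole: Expected Half-Life of Compound 3

The compounds below may be only part of what the source reports. "The series", "measured", "known", "first", "only" and "open" are said of these compounds alone.

Compound 1 `CCCCOC(=O)NS(=O)(=O)c1ccc(CCC)cc1-c1ccc(Cn2c(-c3nccs3)nc3ccccc32)cc1` was tested in an ADME assay on microsomes from liver (Rattus norvegicus, strain Sprague-Dawley) for metabolic stability, read by LC-MS, using NADPH, with stated times of 5 min and 60 min, tested at 1 uM (a higher number here means that the compound lasts longer, a lower number that the compound disappears faster), where compound 1 gives 0.267 h. Among the compounds with values here, this is the lowest of the two numbers measured so far; the nearest is compound 2 `CCCc1ccc(S(=O)(=O)NC(=O)OCCCC(F)(F)F)c(-c2ccc(Cn3c(C(C)(C)C)nc4ccccc43)cc2)c1`, which in this assay gives 0.35 h, a gap that lies within the usual scatter, so the two values cannot be ordered. Compound 3 `CCCCOC(=O)NS(=O)(=O)c1ccc(CCC)cc1-c1ccc(Cn2cnc3ccccc32)cc1` has not yet been measured. It differs from compound 1 by a single change, (hydrogen in place of 1,3-thiazol-2-yl on an aromatic carbon), that is, hydrogen in place of 1,3-thiazol-2-yl on an aromatic carbon. Within the data shown here, no step between measured compounds that shares this change is available, so the expectation rests on compound 1 alone. With nothing comparable to lean on, no step beyond the scatter is expected in this assay in either direction. Compound 3 is therefore estimated at 0.25 h, with a range from 0.1 h to 0.6 h. The step that this estimate means, a 1.1-fold lower number from compound 1 to compound 3 (0.03 log units; within the scatter), is expected to be small.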

Compound 3, half-life: 0.0833 h
The estimate for compound 3 lay 3.0-fold (0.48 log units) above the measured number, and the stated range ends above it.
By their numbers in this assay, from the lowest: compound 3; then compounds 1 and 2 (each within the scatter of the next).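

In this assay, the aromatic carbon between two ring nitrogen atoms emerges as a place where the substituent counts: hydrogen in place of 1,3-thiazol-2-yl gives a 3.2-fold lower number from compound 1 to compound 3 (0.51 log units; beyond the scatter). Within the data shown here, the earlier compounds offered no single-place step, so this is the first reading of any change on the core of compound 1, and it shows that leaving this carbon bare shortens the half-life rather than leaving it unchanged. No measurement bears on what lies behind this step.

One step cannot tell whether the 1,3-thiazol-2-yl ring itself matters or whether any group at this carbon would serve as well. As far as these compounds go, an amine or a pyridyl ring at the same place would help to separate these readings, and whether the step carries over to other cores remains open.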